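Swapping Benzamido for Chloro in a Cytotoxicity Series

A few compounds are considered here, and "the series" means these few. Any claim that something is new, unique, unknown or untested is made for them only; others in the source may bear on it.

Three compounds sharing one core were tested in an ADME assay on PA-1 cells (Homo sapiens) for cytotoxicity, read by MTT assay, with a stated time of 72 h; on this read-out higher numbers stand for weaker inhibition and lower numbers for stronger inhibition. Compound 1, `COc1ccc(C2=C(c3cc(OC)c(OC)c(OC)c3)C(=O)C(OC(C)=O)C2)cc1Cl`, gives > 100 ug/mL, which is a limit of the assay rather than a measured number. Compound 2, `COc1ccc(C2=C(c3cc(OC)c(OC)c(OC)c3)C(=O)C(O)C2)cc1NC(=O)c1ccccc1`, gives > 100 ug/mL in this assay, again a limit. Compound 3, `CCOC(=O)COc1ccc(C2=C(c3cc(OC)c(OC)c(OC)c3)C(=O)CC2O)cc1`, gives > 100 ug/mL in this assay, also a limit. Among the measured compounds shown here, compound 2 therefore stands where every value so far stands: the limit of > 100 ug/mL in this assay, at which 3 of the 3 values shown sit. Compound 4, `COc1ccc(C2=C(c3cc(OC)c(OC)c(OC)c3)C(=O)C(O)C2)cc1Cl`, has not yet been measured. It differs from compound 2 in one place: chloro in place of benzamido on an aromatic carbon. For the measured compounds named here, with no measured step between any two compounds, the data give no direction for this change, so the expected step that the limit leaves unreadable from compound 2 to compound 4 is none beyond the scatter. The estimate for compound 4 is 150 ug/mL, ranging from 60 ug/mL to 400 ug/mL.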

Compound 4, half-maximal inhibitory concentration: > 100 ug/mL
Compound 4 gave a limit, no number; the forecaster's own chance of this, stated with the estimate: 70%; the middle value lies beyond the limit too.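

No step can be read between compound 2 and compound 4, or between compound 1 and compound 4, since each compound gives only a limit: the limit of > 100 ug/mL in this assay, at which 4 of the 4 values shown sit.

The compounds shown leave open whether chloro, benzamido or the acetyl on oxygen changes the result in this assay at all.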